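Methyl on the amide nitrogen of compound 2

The source may hold more compounds than are shown below. What is called first, only, known or untested is meant among the compounds shown, and "the series" means these compounds.

In a physicochemical assay for lipophilicity, using the shake flask method, in phosphate buffer, measured as octanol-water partition, with a stated time of 30 min, at pH 7.4 (on this read-out lower numbers stand for lower lipophilicity and higher numbers for higher lipophilicity), compound 2 (`CNC(=O)c1ccc(-c2cnc(NCc3c(F)ccc4c3CCO4)c3cn[nH]c(=O)c23)c(C)n1`) gives 2.9, the higher of the two numbers available. Compound 1 (`Cc1nc(CN(C)C)ccc1-c1cnc(NCc2c(F)ccc3c2CCO3)c2cn[nH]c(=O)c12`) gives 2.

Compound 3 (`Cc1nc(C(=O)N(C)C)ccc1-c1cnc(NCc2c(F)ccc3c2CCO3)c2cn[nH]c(=O)c12`) has methyl in place of hydrogen on an amide-type nitrogen of compound 2: methyl in place of hydrogen on an amide-type nitrogen.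

Going by the values given here, only one measured step is available: a number 0.90 log units higher from compound 1 to compound 2 (beyond the scatter). It is modest but beyond the scatter, and it puts methylcarbamoyl in place of (dimethylamino)methyl on an aromatic carbon. That step exchanges a whole group, whereas the present change, methylcarbamoyl to dimethylcarbamoyl, alters only the amide-type nitrogen, so it bears on the new step only loosely. Among the compounds with values here, no measured pair isolates this change.

A smaller step than that one is therefore expected in this assay, with no shift beyond the scatter in either direction. The estimated step is a number 0.20 log units lower from compound 2 to compound 3 (within the scatter). For compound 3 the expected value is 2.7, with an estimated range from 2.2 to 3.2.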

Compound 3, distribution coefficient: 2.1
Beside the measured number, compound 3's estimate is 0.60 log units above it, outside the stated range (below it).
By their numbers in this assay, from the lowest: compounds 1 and 3 (each within the scatter of the next); then compound 2.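

At this position the amide-type nitrogen proves sensitive in this assay: methyl in place of hydrogen gives a number 0.80 log units lower from compound 2 to compound 3 (beyond the scatter), so a single added methyl produces a step that, like a number 0.90 log units higher from compound 1 to compound 2 (beyond the scatter), lies beyond the scatter. With a number 0.10 log units higher from compound 1 to compound 3 (within the scatter), the read-out does not separate dimethylcarbamoyl from (dimethylamino)methyl, and the number that set compound 2 apart from compound 1 therefore does not follow the carbonyl alone but is tied, within these three compounds, to methylcarbamoyl with the amide hydrogen still in place. Nothing measured here on these compounds accounts for the step, and the reason stays unexplained.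

As far as these compounds go, the methyl effect rests on one pair, so it remains open whether the plain carbamoyl group, with two hydrogens on the amide nitrogen, would continue the same direction or whether ethylcarbamoyl, with a longer chain on that nitrogen, would behave like methylcarbamoyl or like dimethylcarbamoyl. Also open, from the compounds shown here alone, is where a ring amide such as pyrrolidine-1-carbonyl, or a carboxylic acid at the same aromatic carbon, would fall on this read-out.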